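The source may report more compounds than this note shows. Statements on the series, on what has been measured and on what is new or still open speak of the compounds shown alone.

In an ADME assay on CHO cells (Cricetulus griseus) for cytotoxicity, read by LDH release (a higher number here means a weaker inhibitor, a lower number a stronger inhibitor), three compounds sharing one core have been examined so far. Compound 1 `CC(Oc1ccc(Cl)cc1Cl)C(=O)NC(C)(C)c1ccc(F)cc1` gives > 100000 nM, which is a limit of the assay and not a number. For compound 2 `CC(Oc1ccc(Cl)cc1Cl)C(=O)Nc1ccc(F)cc1` the entry reads "not determined" (no result reported). Within the data shown here, compound 3 `CC(Oc1ccc(Cl)cc1Cl)C(=O)NCc1ccccc1F` gives 47000 nM, the only actual number among the three. Compound 4 `CC(Oc1ccc(Cl)cc1Cl)C(=O)NCc1ccc(F)cn1` carries 5-fluoropyridin-2-yl in place of 2-fluorophenyl on a saturated chain carbon bound to an amide-type nitrogen. Among the measured compounds shown here, no measured step bears on this exchange, so no shift beyond the scatter is expected in this assay. The expected change is a 1.3-fold higher number from compound 3 to compound 4 (0.11 log units; within the scatter). Compound 4 is estimated at 60000 nM, with an expected range from 25000 nM to 100000 nM.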

Compound 4, half-maximal inhibitory concentration: > 100000 nM
Compound 4: no number, only a limit (the forecaster's own chance of this, stated with the estimate: 30%); middle value at least 1.6-fold (0.22 log units) from the limit.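

Among these compounds, replacing 2-fluorophenyl with 5-fluoropyridin-2-yl on the saturated chain carbon bound to an amide-type nitrogen gives the first step that can be read at this position in this assay: an at least 2.1-fold higher number from compound 3 to compound 4 (0.32 log units; beyond the scatter). The exchange of this ring therefore moves the result beyond the scatter, and it does so upward. Its full size stays unknown because compound 4 gives only a limit and not a number: the limit of > 100000 nM in this assay, at which 2 of the 4 values shown sit.

The compounds shown leave open how an unsubstituted pyridin-2-yl, or a longer chain carrying the 5-fluoropyridin-2-yl, would read in this assay.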